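Chloro on the Aryl Ring of Compound 1

The source may report more compounds than this note shows. Statements on the series, on what has been measured and on what is new or still open speak of the compounds shown alone.

Measured compounds:
compound 1 `O=C(NCCCCc1ccccc1)n1cc(-c2ccccc2)oc1=O`, 90 nM
compound 2 `CCCCCNC(=O)n1cc(-c2ccccc2)oc1=O`, 39 nM

Within the data shown here, in an assay on isolated protein for inhibition of acid ceramidase (Homo sapiens), read by LC-MS, with a stated time of 1 h (on this read-out higher numbers stand for weaker inhibition and lower numbers for stronger inhibition), compound 1 gives the higher of the two numbers; the only other measured compound is reached by a 2.3-fold lower number from compound 1 to compound 2 (0.36 log units; beyond the scatter).

Compound 3 `O=C(NCCCCc1ccccc1)n1cc(-c2ccc(Cl)cc2)oc1=O` differs from compound 1 by chloro in place of hydrogen on an aromatic carbon. Among the measured compounds shown here, no measured step touches this aromatic ring: the single step, on the saturated chain, does not bear on it. Compound 3 is therefore expected near the number of compound 1, at 75 nM, between 25 nM and 220 nM. The expected step of a 1.2-fold lower number from compound 1 to compound 3 (0.08 log units; within the scatter) is estimated not to exceed the scatter.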

Compound 3, half-maximal inhibitory concentration: 83 nM
The estimate for compound 3 lay 1.1-fold (0.04 log units) below the measured number; low and high end bracket the measured number.
By their numbers in this assay, from the lowest: compound 2; then compounds 3 and 1 (each within the scatter of the next).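

In this assay the change from phenyl to 4-chlorophenyl gives a 1.1-fold lower number from compound 1 to compound 3 (0.04 log units; within the scatter) and so leaves the number where it was. Among these compounds, this is the first view of this aromatic ring, as the earlier step lay on the saturated chain, and it shows that chloro can stand in place of hydrogen here, para to a large group, without a step beyond the scatter. Nothing at hand offers an explanation for this result. As far as these compounds go, whether methoxy, an amine or a carboxylic acid at this position would leave the number unchanged stays open. So does whether chloro would behave alike on compound 2.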